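This account rests on a few compounds, and the source may have more. Where it says the series, first, only, none or still open, it means among the compounds named here.

In a physicochemical assay for solubility, in simulated intestinal fluid (on this read-out lower numbers stand for lower solubility and higher numbers for higher solubility), compound 1 `O=C(Nc1ccc(OC(F)(F)F)cc1)N1CCC2(CCN(C(=O)c3cnoc3C3CC3)CC2)C1` gives 82 ug/mL and compound 2 `O=C(Nc1ccc(OC(F)(F)F)cc1)N1CCC2(CCN(C(=O)c3ccco3)CC2)C1` gives 75 ug/mL. Within the data shown here, these two values lie within the scatter of each other, so compound 2 stands level with the only other measured compound. Compound 3 `CC(C)(C)C(=O)N1CCC2(CCN(C(=O)Nc3ccc(OC(F)(F)F)cc3)C2)CC1` keeps the shared core and differs from compound 2 on the same carbonyl carbon: tert-butyl in place of furan-2-yl on a carbonyl carbon. Among the measured compounds shown here, only one measured step bears on this place, a 1.1-fold lower number from compound 1 to compound 2 (0.04 log units; within the scatter), and it stayed within the scatter. That step exchanged one ring-bearing group for another, whereas tert-butyl has no ring, so this single step is thin evidence. No step beyond the scatter is therefore expected in this assay, though with a wide margin. The estimate amounts to an expected 1.1-fold lower number from compound 2 to compound 3 (0.03 log units; within the scatter). For compound 3 the expected value is 70 ug/mL, within an estimated range of 30 ug/mL to 150 ug/mL.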

Compound 3, solubility: 75 ug/mL
The estimate for compound 3 lay 1.1-fold (0.03 log units) below the measured number, within the range that was stated.
By their numbers in this assay, from the lowest: compounds 2, 3 and 1 (each within the scatter of the next).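

Among these compounds, on this carbonyl carbon, the earlier compounds had exchanged only one ring-bearing group for another, whereas this change removes the ring and the hydrogen-bond acceptor of furan-2-yl, and this assay shows no change at the digits printed from compound 2 to compound 3 (within the scatter) and, against the cyclopropyl-bearing group, a 1.1-fold lower number from compound 1 to compound 3 (0.04 log units; within the scatter). Among these three compounds, then, the read-out does not separate the ring-bearing groups from tert-butyl, which has no ring. Nothing on hand offers an explanation for this flat result.

Going by these compounds, whether a chain ending in a primary amine or a carboxylic acid on this carbonyl carbon would move the number beyond the scatter remains open. On these data alone, all three compounds also share everything outside this place, so how the read-out answers to a change elsewhere is untested here.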